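The source may hold more compounds than are shown below. What is called first, only, known or untested is meant among the compounds shown, and "the series" means these compounds.

Measured so far: compound 1 `NC(=O)c1c(NC(=O)c2ccccc2Cl)sc2c1CCN(C(=S)Nc1cccc3ccccc13)C2` with 13400 nM, and compound 2 `COc1ccccc1NC(=S)N1CCc2c(sc(NC(=O)c3ccccc3Cl)c2C(N)=O)C1` with 40900 nM, both in a functional assay on HL-60 cells (Homo sapiens) for antiproliferative activity, with a stated time of 24 h; a lower number here means a stronger inhibitor, a higher number a weaker inhibitor.

Compound 2 stands with the highest of the two numbers; the step of a 3.1-fold higher number from compound 1 to compound 2 (0.48 log units; beyond the scatter) separates it from compound 1. Compound 3 `NC(=O)c1c(NC(=O)c2ccccc2Cl)sc2c1CCN(C(=S)Nc1ccccc1-c1ccccc1)C2` differs from compound 2 by phenyl in place of methoxy on an aromatic carbon, placed ortho to a large group. Within the data shown here, the only step that bears on this change is a 3.1-fold higher number from compound 1 to compound 2 (0.48 log units; beyond the scatter), where a single aromatic ring with a methoxy replaced a fused two-ring aromatic group. Adding an aromatic ring again points back toward a lower number, and compound 3 is therefore expected to give 15000 nM (range 5000 nM to 45000 nM), a step of a 2.7-fold lower number from compound 2 to compound 3 (0.44 log units; beyond the scatter) that is estimated to be modest.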

Compound 3, half-maximal inhibitory concentration: 34400 nM
Compound 3: the middle estimate sits 2.3-fold (0.36 log units) below what was measured, within the range that was stated.
By their numbers in this assay, from the lowest: compound 1; then compounds 3 and 2 (each within the scatter of the next).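

In this assay, phenyl in place of methoxy on an aromatic carbon, ortho to a large group, gives a 1.2-fold lower number from compound 2 to compound 3 (0.08 log units; within the scatter) and so leaves the two groups indistinguishable at this position. The 2-phenylphenyl group, with a 2.6-fold higher number from compound 1 to compound 3 (0.41 log units; beyond the scatter) in the other comparison, does not match the naphthalen-1-yl group, so an added unfused aromatic ring does not restore the number of compound 1. Nothing available explains this result.

On these data alone, whether an amine or a carboxylic acid at this place would shift the number remains open.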